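The source may hold more compounds than are shown below. What is called first, only, known or untested is meant among the compounds shown, and "the series" means these compounds.

Compound 2 `Cc1c(O)ccc2c1[C@H](Cn1cc(-c3ccc(Cl)cc3)nn1)[C@@]13CC(=O)[C@@](C)(CC[C@@H]21)C3` is the reference point for this step. In a functional assay on SW480 cells (Homo sapiens) for cytotoxicity, read by MTT assay, with a stated time of 4 days (a lower number here means a stronger inhibitor, a higher number a weaker inhibitor), compound 2 gives only a limit of the assay, > 20000 nM. Compound 1 `Cc1c(O)ccc2c1[C@H](Cn1cc(-c3ccccc3)nn1)[C@@]13CC(=O)[C@@](C)(CC[C@@H]21)C3` lacks the chloro on the phenyl ring. In this assay compound 1 likewise gives only a limit of the assay, > 20000 nM. The step that the two limits leave unreadable from compound 1 to compound 2 is therefore not readable, since both values share (the limit of > 20000 nM in this assay, at which 2 of the 2 values shown sit), and nothing about direction or size can be drawn from this pair.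

Compound 3 `Cc1c(O)ccc2c1[C@H](Cn1cc(-c3ccccn3)nn1)[C@@]13CC(=O)[C@@](C)(CC[C@@H]21)C3` differs from compound 2 by pyridin-2-yl in place of 4-chlorophenyl on an aromatic carbon. Within the data shown here, no measured step in the set bears on this replacement: the only step available, from compound 1 to compound 2, concerns the chloro and is unreadable. The expectation for compound 3 in this assay therefore rests on compound 2 alone, which stands at the limit of the assay. Compound 3 is expected to remain at or near that limit, with a step that the limit leaves unreadable from compound 2 to compound 3 expected to be no larger than the scatter. Compound 3 is estimated at 30000 nM, with a range from 10000 nM to 100000 nM.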

Compound 3, half-maximal inhibitory concentration: > 20000 nM
Compound 3 gave a limit, no number; the forecaster's own chance of this, stated with the estimate: 80%; the middle value is on the limit's open side.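

In this assay compound 3 gives > 20000 nM, a limit and not a number. The steps among compound 1, compound 2 and compound 3 cannot be read because all three values sit at one limit: the limit of > 20000 nM in this assay, at which 3 of the 3 values shown sit.

The compounds shown leave open how the phenyl, 4-chlorophenyl and pyridin-2-yl groups rank against one another in this assay.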